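A few compounds are considered here, and "the series" means these few. Any claim that something is new, unique, unknown or untested is made for them only; others in the source may bear on it.

Measured compounds:
- compound 1 `COC(=O)C1=C(C)NC(=O)N(C(=O)NCCCN2CCN(c3ccccc3O)CC2)C1c1ccc(F)c(F)c1`: 31 nM in an assay on liver for binding affinity to Alpha-1D adrenergic receptor (Homo sapiens), using microsomes; a higher number here means a weaker inhibitor, a lower number a stronger inhibitor
- compound 2 `COC(=O)C1=C(C)NC(=O)N(C(=O)NCCCN2CCN(c3cccc(Cl)c3)CC2)C1c1ccc(F)c(F)c1`: 37 nM in this assay

Going by the values given here, compound 2 holds the higher of the two numbers, but its only neighbour is compound 1, and the move a 1.2-fold higher number from compound 1 to compound 2 (0.08 log units; within the scatter) is within the scatter, so the two compounds cannot be told apart on these data.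

Compound 3 `COC(=O)C1=C(C)NC(=O)N(C(=O)NCCCN2CCN(c3ccc(OC)cc3C)CC2)C1c1ccc(F)c(F)c1` differs from compound 2 in one place: 4-methoxy-2-methylphenyl in place of 3-chlorophenyl on an amine nitrogen in a ring. Among the compounds with values here, the only measured step that bears on this position is the one from compound 1 to compound 2, where one aryl group on the same ring nitrogen was exchanged for another; that exchange moved the number by a 1.2-fold higher number from compound 1 to compound 2 (0.08 log units; within the scatter), within the scatter. On this single precedent an exchange of the aryl group at that nitrogen is expected to leave this assay essentially where it is, with no step beyond the scatter in either direction. Compound 3 is therefore expected to come in at 38 nM, with a range from 12 nM to 120 nM. That expectation means a step of a 1.0-fold higher number from compound 2 to compound 3 (0.01 log units; within the scatter), which is within the scatter.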

Compound 3, inhibition constant: 610 nM
Beside the measured number, compound 3's estimate is 16-fold (1.21 log units) below it; measured number above the stated range.
By their numbers in this assay, from the lowest: compounds 1 and 2 (each within the scatter of the next); then compound 3.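

In this assay, the aryl group on the amine nitrogen in a ring proves able to move the number far more than the first exchange suggested: 4-methoxy-2-methylphenyl gives a 16-fold higher number from compound 2 to compound 3 (1.22 log units; beyond the scatter), and against 2-hydroxyphenyl it gives a 20-fold higher number from compound 1 to compound 3 (1.29 log units; beyond the scatter). Both steps are large, whereas 2-hydroxyphenyl and 3-chlorophenyl lie within the scatter of each other, so among these three compounds the position accepts two of the aryl groups alike and separates the third from them. Nothing shown here accounts for the size of these steps, and the data cannot say what about the entering group lies behind them.

The entering group differs from the other two in more than one feature, so the compounds shown leave open whether the methoxy group, the methyl group or the two together carry the step; 4-methoxyphenyl and 2-methylphenyl on the same nitrogen would separate these. Also open, on these data alone, is whether the step would persist with a different group at that nitrogen, such as a pyridyl ring, or with a longer chain between the urea-type carbonyl and the ring.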